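From Butoxycarbonyl to Isobutoxycarbonyl in Compound 3

A few compounds are considered here, and "the series" means these few. Any claim that something is new, unique, unknown or untested is made for them only; others in the source may bear on it.

Among the compounds with values here, compound 1 (`COC(=O)c1cc(N2C(=O)C3=C(CCCC3)C2=O)c(F)cc1Cl`) gives 170 nM in a functional assay on the whole organism with Scenedesmus acutus as the target, with a stated time of 20 h (on this read-out higher numbers stand for weaker inhibition and lower numbers for stronger inhibition), and compound 2 (`CCCCOC(=O)c1cc(N2C(=O)C3=C(CCCC3)C2=O)c(F)cc1Cl`) gives 141 nM there, two values within the usual scatter of each other, so compound 2 stands level with the only other measured compound. Compound 3 (`CC(C)COC(=O)c1cc(N2C(=O)C3=C(CCCC3)C2=O)c(F)cc1Cl`) has the same atoms as compound 2, joined differently (isopropyl in place of propyl on a saturated chain carbon bound to an oxygen next to a carbonyl group): isopropyl in place of propyl on a saturated chain carbon bound to an oxygen next to a carbonyl group, which reads butyl to isobutyl one bond further out. Within the data shown here, the one measured step that bears on this lies at that same place, with propyl in place of hydrogen (a 1.2-fold lower number from compound 1 to compound 2 (0.08 log units; within the scatter)). So no step beyond the scatter is expected in this assay here, and no direction can be favoured. The estimated change is small (a 1.1-fold higher number from compound 2 to compound 3 (0.03 log units; within the scatter)). For compound 3 the expected value is 150 nM (estimated range 70 nM to 320 nM).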

Compound 3, half-maximal inhibitory concentration: 407 nM
Estimate against measurement, compound 3: 2.7-fold (0.43 log units) below, and the stated range ends below it.
By their numbers in this assay, from the lowest: compounds 2 and 1 (each within the scatter of the next); then compound 3.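

Moving the same atoms in this chain matters in this assay: isobutyl in place of butyl gives a 2.9-fold higher number from compound 2 to compound 3 (0.46 log units; beyond the scatter), whereas the only earlier step at this position stayed within the scatter. Compound 3 also compares poorly with the smaller ester, with a 2.4-fold higher number from compound 1 to compound 3 (0.38 log units; beyond the scatter) as the printed step, so it is the weakest inhibitor of the three, and the arrangement of the chain, not just its size, affects the read-out. Nothing available explains why this rearrangement weakens inhibition.

Going by these compounds, whether other branched or ring-bearing esters, such as a tert-butyl or a benzyl ester, fall with compound 3 or stay level with compound 2 remains open. So does the effect of a longer straight chain, such as hexyl, or of an amide or a carboxylic acid in place of the ester.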